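From 2,4-difluorobenzyl to benzyl: compound 2 to compound 3

The source may hold more compounds than are shown below. What is called first, only, known or untested is meant among the compounds shown, and "the series" means these compounds.

Going by the values given here, in a functional assay on HeLa cells (Homo sapiens) for antiproliferative activity, read by MTT assay, with a stated time of 48 h (a higher number here means a weaker inhibitor, a lower number a stronger inhibitor), compound 1 (`Fc1ccc(CSc2nnc(-c3cnccn3)n2-c2ccccc2)cc1`) gives 7300 nM and compound 2 (`Fc1ccc(CSc2nnc(-c3cnccn3)n2-c2ccccc2)c(F)c1`) gives 12500 nM in the same read-out, so compound 2 sits within the scatter of compound 1, the only other measured compound. Compound 3 (`c1ccc(CSc2nnc(-c3cnccn3)n2-c2ccccc2)cc1`) differs from compound 2 by phenyl in place of 2,4-difluorophenyl on a saturated chain carbon bound to a sulfur with phenyl in place of 2,4-difluorophenyl on a saturated chain carbon bound to a sulfur. Among the compounds with values here, the only measured step bearing on this is fluoro in place of hydrogen on an aromatic carbon, which gave a 1.7-fold higher number from compound 1 to compound 2 (0.23 log units; within the scatter) and so offers no ground to expect a step beyond the scatter for compound 3 in this assay in either direction. Within the data shown here, no measured compound carries the plain benzyl group, so that part of the change is untested. The expected step is a 1.4-fold lower number from compound 2 to compound 3 (0.14 log units; within the scatter) by this estimate. For compound 3 the estimate is 9000 nM within an expected range from 4000 nM to 20000 nM as a working figure.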

Compound 3, half-maximal inhibitory concentration: 35600 nM
Estimate against measurement, compound 3: 4.0-fold (0.60 log units) below; the measured number lies above the stated range.
By their numbers in this assay, from the lowest: compounds 1 and 2 (each within the scatter of the next); then compound 3.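

In this assay, going by these compounds alone, the plain benzyl group gives the first change at this position that goes beyond the scatter: a 2.8-fold higher number from compound 2 to compound 3 (0.45 log units; beyond the scatter), and a 4.9-fold higher number from compound 1 to compound 3 (0.69 log units; beyond the scatter). Compound 3 is therefore the weakest of the three, with steps to both fluorinated compounds beyond the scatter, whereas compound 1 and compound 2 remain within the scatter of each other. On a saturated chain carbon bound to a sulfur, having fluoro on the phenyl goes with lower numbers in these compounds, and the data shown offer no explanation for this.

Still open, as far as these compounds go, is whether this difference is specific to fluoro or would also appear with chloro or methoxy on the phenyl. A longer chain between the sulfur and the phenyl, and the effect of the same change on other versions of the shared core, also remain to be seen.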